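Sodium/hydrogen exchanger series: ether to aminopyrimidine switch

A few compounds are considered here, and "the series" means these few. Any claim that something is new, unique, unknown or untested is made for them only; others in the source may bear on it.

Compound 1, `Cc1cc(OC2CCCC2)c(S(C)(=O)=O)cc1C(=O)N=C(N)N`, in a functional assay for inhibition of sodium/hydrogen exchanger (Oryctolagus cuniculus); on this read-out lower numbers stand for stronger inhibition and higher numbers for weaker inhibition: 27 nM
Compound 2, `Cc1cc(OC(C)(C)C)c(S(C)(=O)=O)cc1C(=O)N=C(N)N`, in this assay: 9.4 nM

Going by the values given here, compound 2 holds the lowest of the two numbers measured so far; the only measured step is a 2.9-fold lower number from compound 1 to compound 2 (0.46 log units; beyond the scatter). Compound 3, `Cc1cc(Nc2ncccn2)c(S(C)(=O)=O)cc1C(=O)N=C(N)N`, is not yet measured. ((pyrimidin-2-yl)amino in place of tert-butoxy on an aromatic carbon). The measured step concerns tert-butyl in place of cyclopentyl on the same oxygen, so it speaks only to the group carried by that oxygen; it says nothing about exchanging the oxygen-linked group for a nitrogen-linked aromatic ring. Among the compounds with values here, no measured step therefore bears directly on the change to compound 3, and neither direction can be read from the numbers at hand. With compound 2 as the only anchor, the step to compound 3 is expected to be small, a 2.1-fold higher number from compound 2 to compound 3 (0.33 log units; beyond the scatter), with a wide range. Compound 3 is thus estimated at 20 nM, between 5 nM and 80 nM.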

Compound 3, half-maximal inhibitory concentration: 8.3 nM
Estimate against measurement, compound 3: 2.4-fold (0.38 log units) above; measured number inside the range.
By their numbers in this assay, from the lowest: compounds 3 and 2 (each within the scatter of the next); then compound 1.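

In this assay, the position ortho to a methylsulfonyl group takes (pyrimidin-2-yl)amino in place of tert-butoxy with a 1.1-fold lower number from compound 2 to compound 3 (0.05 log units; within the scatter), so an aromatic ring linked through nitrogen serves here as well as the branched ether, although the two groups differ in ring content, heavy atoms and hydrogen-bond donors. In place of cyclopentyloxy, the same group gives a 3.3-fold lower number from compound 1 to compound 3 (0.51 log units; beyond the scatter), which puts the new group, like tert-butoxy, on the side of lower numbers relative to cyclopentyloxy. Nothing available explains why such different groups give values within the scatter of each other.

Open, as far as these compounds go, is whether the ring nitrogens of the pyrimidine matter, which a phenylamino group would test. Also open, from the compounds shown here alone, is the role of the linking amino hydrogen, which a methylated linking nitrogen or a pyrimidin-2-yloxy group would address.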